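Swapping sec-butyl for cyclopropyl: an expected growth inhibition value

A few compounds are considered here, and "the series" means these few. Any claim that something is new, unique, unknown or untested is made for them only; others in the source may bear on it.

compound 1 `CCC(C#CC(=O)OC)O/C=C/C(=O)OC`: 320 nM
compound 2 `CCC(C)C(C#CC(=O)OC)O/C=C/C(=O)OC`: 340 nM

In a functional assay on HBL-100 cells (Homo sapiens) for antiproliferative activity, read by sulforhodamine B assay, with a stated time of 48 h (a lower number here means a stronger inhibitor of growth, a higher number a weaker inhibitor of growth), compound 2 gives 340 nM, which lies within the scatter of compound 1. Compound 3 `COC(=O)C#CC(O/C=C/C(=O)OC)C1CC1` has not yet been measured. It differs from compound 2 as follows: cyclopropyl in place of sec-butyl on a saturated chain carbon bound to an oxygen on an unsaturated carbon and a triple-bonded carbon. Within the data shown here, only one measured step bears on this change, a change within the same group: a 1.1-fold higher number from compound 1 to compound 2 (0.03 log units; within the scatter). Among the measured compounds shown here, no measured compound carries a ring at this place, so this step is a limited guide. In this assay, no shift beyond the scatter is therefore expected. The expected step is a 1.0-fold lower number from compound 2 to compound 3 (0.01 log units; within the scatter). For compound 3, the estimated value is 330 nM, with an expected range of 140 nM to 750 nM.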

Compound 3, concentration for 50% growth inhibition: 250 nM
Beside the measured number, compound 3's estimate is 1.3-fold (0.12 log units) above it; low and high end bracket the measured number.
By their numbers in this assay, from the lowest: compounds 3, 1 and 2 (each within the scatter of the next).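

In this assay, a ring at this place can now be set against open chains: there is a 1.4-fold lower number from compound 2 to compound 3 (0.13 log units; within the scatter) and a 1.3-fold lower number from compound 1 to compound 3 (0.11 log units; within the scatter). Cyclopropyl, with its three-membered ring, therefore cannot be told apart from sec-butyl or ethyl on this saturated chain carbon. No outside data bear on this result. Still open, on these data alone, is whether any group at this place moves the number beyond the scatter. An amine, a carboxylic acid, a longer chain or a larger ring such as cyclohexyl could each test that.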